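Changing the aniline on an anilinoquinazoline sulfonamide series

The compounds below may be only part of what the source reports. "The series", "measured", "known", "first", "only" and "open" are said of these compounds alone.

Measured compounds:
compound 1 `COc1cc2ncnc(Nc3ccc(C(F)(F)F)cc3)c2cc1OCCCCC(=O)Nc1ccc(S(N)(=O)=O)cc1`, 16900 nM
compound 2 `COc1cc2ncnc(Nc3ccc(C)cc3)c2cc1OCCCCC(=O)Nc1ccc(S(N)(=O)=O)cc1`, 35500 nM
compound 3 `NS(=O)(=O)c1ccc(NC(=S)Nc2ccc3ncnc(Nc4ccc(F)c(Cl)c4)c3c2)cc1`, 37600 nM

In a functional assay on A-431 cells (Homo sapiens) for antiproliferative activity, read by MTT assay, with a stated time of 72 h (a lower number here means a stronger inhibitor, a higher number a weaker inhibitor), compound 3 gives 37600 nM, the highest of the three numbers; its value sits within the scatter of compound 2, while compound 1 gives a number beyond the scatter lower than that of compound 3. Compound 4 `NS(=O)(=O)c1ccc(NC(=S)Nc2ccc3ncnc(Nc4cccc(Br)c4)c3c2)cc1` differs from compound 3 by 3-bromophenyl in place of 3-chloro-4-fluorophenyl on a nitrogen on an aromatic ring. Among the measured compounds shown here, the only measured step, a 2.1-fold higher number from compound 1 to compound 2 (0.32 log units; beyond the scatter), concerns a different exchange on a different scaffold, so no measured step bears directly on the change from compound 3 to compound 4. The data give no guide for replacing one halogenated phenyl with another on this nitrogen. With nothing to point in either direction, compound 4 is expected to stay close to compound 3, with a step of a 1.1-fold lower number from compound 3 to compound 4 (0.03 log units; within the scatter) that is expected to lie within the scatter. The estimate for compound 4 in this assay is therefore 35000 nM, with an expected range from 12000 nM to 100000 nM.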

Compound 4, half-maximal inhibitory concentration: 20700 nM
The estimate for compound 4 lay 1.7-fold (0.23 log units) above the measured number, within the range that was stated.
By their numbers in this assay, from the lowest: compounds 1, 4, 2 and 3 (each within the scatter of the next, the first and the last beyond it).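

In this assay, replacing 3-chloro-4-fluorophenyl with 3-bromophenyl on the nitrogen gives a 1.8-fold lower number from compound 3 to compound 4 (0.26 log units; within the scatter), so this exchange on the shared core of compound 3 and compound 4 cannot be told apart from repeat scatter. Among the compounds shown here, this is the first reading of any change at this place, as the only earlier step concerned a different exchange on a different scaffold. No available evidence bears on this result.

On these data alone, it remains open whether a group of another kind on this phenyl ring, such as an amine or a carboxylic acid, would move the number beyond the scatter. As far as these compounds go, it is also open whether an unsubstituted phenyl on this nitrogen would do so, and the two halogenated compounds alone cannot settle either question.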